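A few compounds are considered here, and "the series" means these few. Any claim that something is new, unique, unknown or untested is made for them only; others in the source may bear on it.

Measured compounds in a functional assay on DU-145 cells (Homo sapiens) for inhibition, read by trypan blue exclusion, with a stated time of 96 h; on this read-out higher numbers stand for weaker inhibition of growth and lower numbers for stronger inhibition of growth:
- compound 1 `Cc1ccc(S/C(=C/c2c[nH]c3ccccc23)C(=O)c2ccc(Cl)cc2)cc1`: 10000 nM
- compound 2 `COc1ccc(/C=C(/SCc2ccc(Cl)cc2)C(=O)c2ccc(Cl)cc2)cc1`: 10000 nM
- compound 3 `Cc1ccc(S/C(=C/c2c(O)cc(O)cc2O)C(=O)c2ccc(Cl)cc2)cc1`: > 100000 nM

Compound 3 sits at the weak end of what has been measured: its value in this assay is only a limit of the assay, (the limit of > 100000 nM in this assay, at which 1 of the 3 values shown sits), and not a number. Among the measured compounds shown here, compound 1 and compound 2 both give numbers in this assay, and the one measured step that bears here, an at least 10-fold higher number from compound 1 to compound 3 (1.00 log units; beyond the scatter), shows that putting 2,4,6-trihydroxyphenyl onto the core of compound 1 costs growth inhibition.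

The step now followed runs the other way. Compound 4 `COc1ccc(/C=C(/Sc2ccc(C)cc2)C(=O)c2ccc(Cl)cc2)cc1` is compound 3 with 4-methoxyphenyl in place of 2,4,6-trihydroxyphenyl on a double-bonded chain carbon bound to a double-bonded chain carbon. This undoes the trihydroxyphenyl and installs a group that compound 2 also bears, and compound 2 gives 10000 nM in this assay. Since compound 3 is known only as a limit, the step from compound 3 to compound 4 can only be bounded; compound 4 is expected to return to the range where compound 1 and compound 2 sit, an expected step of an at least 10-fold lower number from compound 3 to compound 4 (1.00 log units; beyond the scatter).

In this assay compound 4 is therefore estimated at 10000 nM, with a range from 3000 nM to 50000 nM.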

Compound 4, concentration for 50% growth inhibition: 1000 nM
Beside the measured number, compound 4's estimate is 10-fold (1.00 log units) above it, and the stated range ends above it.
By their numbers in this assay, from the lowest: compound 4; then compounds 1 and 2 (each within the scatter of the next). At a limit, above all of these: compound 3.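

In this assay, an at least 100-fold lower number from compound 3 to compound 4 (2.00 log units; beyond the scatter), so on a double-bonded chain carbon bound to a double-bonded chain carbon, 4-methoxyphenyl is far better tolerated than 2,4,6-trihydroxyphenyl. The value for compound 3 is a limit and not a number, which makes this step a bound only: the limit of > 100000 nM in this assay, at which 1 of the 4 values shown sits. Two further steps give numbers on both sides: at the same place, 4-methoxyphenyl also outperforms 1H-indol-3-yl, with a 10-fold lower number from compound 1 to compound 4 (1.00 log units; beyond the scatter), and on the sulfur, 4-methylphenyl outperforms 4-chlorobenzyl, with a 10-fold lower number from compound 2 to compound 4 (1.00 log units; beyond the scatter).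

The compounds shown leave open whether a single hydroxyl, an amine or a carboxylic acid in place of the methoxy group would keep growth inhibition. They also do not separate the ring substituent from the extra carbon on the sulfur; a 4-chlorophenyl or a 4-methylbenzyl group there would do so.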